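Aldehyde to Bisulfite Adduct: Expected Cytotoxicity

This account rests on a few compounds, and the source may have more. Where it says the series, first, only, none or still open, it means among the compounds named here.

Compound 1, `COc1cccc2[nH]c(C(=O)N[C@@H](CC(C)C)C(=O)N[C@H](C=O)C[C@@H]3CCNC3=O)cc12` — in an ADME assay on Vero C1008 cells (Chlorocebus sabaeus) for cytotoxicity, read by luminescence and CellTiter-Glo, with a stated time of 24 h (on this read-out lower numbers stand for higher toxicity in this test and higher numbers for lower toxicity in this test), compound 1 gives > 200000 nM, a limit of the assay rather than a number.
Compound 2, `COc1cccc2[nH]c(C(=O)N[C@@H](CC3CC3)C(=O)N[C@H](C=O)C[C@@H]3CCNC3=O)cc12` — in this assay compound 2 gives > 200000 nM, also a limit.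

Compound 1 therefore stands only at a limit: the limit of > 200000 nM in this assay, at which 2 of the 2 values shown sit. Going by the values given here, the one measured step, a step that the two limits leave unreadable from compound 1 to compound 2, cannot be sized from two limits. Compound 3, `COc1cccc2[nH]c(C(=O)N[C@@H](CC(C)C)C(=O)N[C@@H](C[C@@H]3CCNC3=O)C(O)S(=O)(=O)O)cc12`, differs from compound 1 by hydroxy(sulfo)methyl in place of formyl on a saturated chain carbon bound to an amide-type nitrogen and a saturated chain carbon. No readable step bears on this change, so compound 3 is expected to stay at the limit, a step that the limit leaves unreadable from compound 1 to compound 3. Compound 3 is estimated at 300000 nM, within 150000 nM to 1000000 nM.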

Compound 3, half-maximal cytotoxic concentration: > 200000 nM
Compound 3 ended at the assay's limit (the forecaster's own chance of this, stated with the estimate: 85%); the middle value does not contradict the limit.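

Going by these compounds alone, compound 1 and compound 3 both stand at a limit of the assay, not at a number, so no step between them can be read: the limit of > 200000 nM in this assay, at which 3 of the 3 values shown sit.

Going by these compounds, whether hydroxy(sulfo)methyl in place of formyl changes the half-maximal cytotoxic concentration at all in this assay stays open.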